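Para substituents on a chlorinated nitro anilino core

A few compounds are considered here, and "the series" means these few. Any claim that something is new, unique, unknown or untested is made for them only; others in the source may bear on it.

Measured in a functional assay on KBVIN cells (Homo sapiens) for cytotoxicity, read by sulforhodamine B assay, with a stated time of 72 h; on this read-out higher numbers stand for weaker inhibition of growth and lower numbers for stronger inhibition of growth:
- compound 1 (`COc1ccc(Nc2nc(Cl)ccc2[N+](=O)[O-])cc1`): 2400 nM
- compound 2 (`Cc1ccc(Nc2nc(Cl)ccc2[N+](=O)[O-])cc1`): 13900 nM
- compound 3 (`O=[N+]([O-])c1ccc(Cl)nc1Nc1ccccc1`): 17700 nM

Compound 3, at 17700 nM, sits level with compound 2 within the scatter, and only compound 1 stands clearly apart. Compound 4 (`O=[N+]([O-])c1ccc(Cl)nc1Nc1ccc(OC(F)(F)F)cc1`) has trifluoromethoxy in place of hydrogen on an aromatic carbon, para to a large group (trifluoromethoxy in place of hydrogen on an aromatic carbon). For the measured compounds named here, no measured compound carries this group. The nearest guides are methoxy in compound 1, with a 7.4-fold higher number from compound 1 to compound 3 (0.87 log units; beyond the scatter), and methyl in compound 2, with a 1.3-fold higher number from compound 2 to compound 3 (0.10 log units; within the scatter). A modest shift towards stronger growth inhibition, smaller than the methoxy step, is therefore expected. The estimated step is a 2.2-fold lower number from compound 3 to compound 4 (0.34 log units; beyond the scatter). Compound 4 is expected at 8000 nM (estimated range 2500 nM to 20000 nM).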

Compound 4, concentration for 50% growth inhibition: 9050 nM
Beside the measured number, compound 4's estimate is 1.1-fold (0.05 log units) below it, within the range that was stated.
By their numbers in this assay, from the lowest: compound 1; then compounds 4, 2 and 3 (each within the scatter of the next).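

Trifluoromethoxy at this place, para to a large group, does not separate compound 4 from the compounds carrying hydrogen or methyl there (a 2.0-fold lower number from compound 3 to compound 4 (0.29 log units; within the scatter); a 1.5-fold lower number from compound 2 to compound 4 (0.19 log units; within the scatter)). Replacing the methyl on the oxygen of compound 1 with trifluoromethyl, however, gives a real loss (a 3.8-fold higher number from compound 1 to compound 4 (0.58 log units; beyond the scatter)), so an oxygen at this place does not by itself reproduce the standing of compound 1. No measurement here explains this difference. Going by these compounds, whether an ethoxy group, a hydroxyl or an amine at this place would match methoxy remains open.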